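A few compounds are considered here, and "the series" means these few. Any claim that something is new, unique, unknown or untested is made for them only; others in the source may bear on it.

The measured compounds and their values in a functional assay on CHO cells with adenosine receptor A1 (Homo sapiens) as the target, read by cAMP accumulation and immunoassay, with a stated time of 6 min, tested at 1 uM; on this read-out higher numbers stand for a weaker effect at the one concentration tested and lower numbers for a stronger effect:
compound 1, `CC(C)N1CCN(Cc2csc(N)c2C(=O)c2ccc(Cl)cc2)CC1`, gives 7.3%;
compound 2, `Nc1scc(CN2CCN(c3ccc(F)cc3Cl)CC2)c1C(=O)c1ccc(Cl)cc1`, gives -39%;
compound 3, `Nc1scc(CN2CCN(c3c(F)cccc3F)CC2)c1C(=O)c1ccc(Cl)cc1`, gives -65%.

Compound 3 stands lowest of the three numbers in this assay. Its nearest neighbour is compound 2, with a number 26 percentage points lower from compound 2 to compound 3 (beyond the scatter), and its furthest is compound 1, with a number 72.3 percentage points lower from compound 1 to compound 3 (beyond the scatter). The three compounds share one core and differ only in the group on the amine nitrogen in a ring. Compound 4, `Nc1scc(CN2CCN(c3ccc(F)c(Cl)c3)CC2)c1C(=O)c1ccc(Cl)cc1`, has not yet been measured. It differs from compound 3 in one place: 3-chloro-4-fluorophenyl in place of 2,6-difluorophenyl on an amine nitrogen in a ring.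

Within the data shown here, the steps that bear on this change are the three exchanges of the group on that ring nitrogen. Going from isopropyl to a halogenated phenyl gave large steps, a number 46.3 percentage points lower from compound 1 to compound 2 (beyond the scatter) and a number 72.3 percentage points lower from compound 1 to compound 3 (beyond the scatter). Going from one halogenated phenyl to another gave a modest step, a number 26 percentage points lower from compound 2 to compound 3 (beyond the scatter). Compound 4 again carries a halogenated phenyl on the ring nitrogen, and its number in this assay is expected to lie nearer to compound 2 and compound 3 than to compound 1. For compound 4 a modest step upward is expected, a number 20 percentage points higher from compound 3 to compound 4 (beyond the scatter). Compound 4 is therefore estimated at -45%, with a range from -80% to -10%.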

Compound 4, a percentage reported as activity, at one concentration (the size of the read-out at that concentration, not a potency): -60%
Compound 4: the middle estimate sits 15 percentage points above what was measured, and the stated range covers the measured number.
By their numbers in this assay, from the lowest: compounds 3 and 4 (each within the scatter of the next); then compound 2; then compound 1.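

In this assay, 3-chloro-4-fluorophenyl in place of 2,6-difluorophenyl on the amine nitrogen in a ring gives a number 5 percentage points higher from compound 3 to compound 4 (within the scatter), so two phenyl groups carrying different halogens cannot be told apart on this read-out. The exchange of 2-chloro-4-fluorophenyl for 3-chloro-4-fluorophenyl, two names that differ only in the number of the chlorine, gives a number 21 percentage points lower from compound 2 to compound 4 (beyond the scatter), which shows that the place of the chlorine on this phenyl alone can shift the read-out beyond the scatter, something the earlier pair, which also differed in its halogens, could not separate. The step of a number 67.3 percentage points lower from compound 1 to compound 4 (beyond the scatter) adds a third halogenated phenyl to the large steps away from isopropyl, so all three such groups on this nitrogen now stand well under the isopropyl compound.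

Nothing at hand gives a reason for any of these steps. The compounds shown leave open how a phenyl with no halogen, a phenyl bearing a methoxy group or a benzyl group on the same nitrogen would read in this assay.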